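The source may hold more compounds than are shown below. What is called first, only, known or untested is meant among the compounds shown, and "the series" means these compounds.

In an ADME assay on microsomes from liver (Homo sapiens) for metabolic stability (on this read-out lower numbers stand for a shorter-lived compound and higher numbers for a longer-lived compound), compound 1 (`COc1cc(OCc2csc(-c3ccc(C(F)(F)F)cc3)n2)c2cc(-c3cn4nc(OC)sc4n3)oc2c1`) gives > 2 h as a limit of the assay, not a number. Its standing rests on that alone (the limit of > 2 h in this assay, at which 1 of the 3 values shown sits). Compound 2 (`COc1cc(OCc2cccc(-c3ccc(C(F)(F)F)cn3)c2)c2cc(-c3cn4nc(OC)sc4n3)oc2c1`) gives 0.733 h and compound 3 (`COc1cc(OCc2cccc(-c3cnc(OC)nc3)c2)c2cc(-c3cn4nc(OC)sc4n3)oc2c1`) gives 0.6 h on the same read-out. Compound 4 (`COc1cc(OCc2csc(-c3ccc(C(C)(C)O)cc3)n2)c2cc(-c3cn4nc(OC)sc4n3)oc2c1`) carries one change from compound 1 (1-hydroxy-1-methylethyl in place of trifluoromethyl on an aromatic carbon): 1-hydroxy-1-methylethyl in place of trifluoromethyl on an aromatic carbon. Going by the values given here, no measured step covers this change. Among the compounds with values here, the only measured step is a different replacement on another part of the series (a 1.2-fold lower number from compound 2 to compound 3 (0.09 log units; within the scatter)), and it is small. On that thin basis, no shift beyond the scatter is expected in this assay for the estimated step (a number no higher from compound 1 to compound 4 (the limit leaves the size open)) here. Compound 4 is estimated at 2 h with an expected range from 0.9 h to 4 h on that read-out.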

Compound 4, half-life: 1.83 h
Estimate against measurement, compound 4: 1.1-fold (0.04 log units) above; the range from low to high includes it.
By their numbers in this assay, from the lowest: compounds 3 and 2 (each within the scatter of the next); then compound 4. At a limit, above all of these: compound 1.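

At this place, on a six-membered aromatic ring of carbon only and para to a large group, 1-hydroxy-1-methylethyl adds to the hydrogen-bond donors and acceptors, and in this assay the change gives an at least 1.0-fold lower number from compound 1 to compound 4 (0.03 log units; that floor lies within the scatter) as its reading. As far as these compounds go, that floor shows no shift beyond the scatter, while the full size of the step stays open. The reading for compound 1 is a limit, not a number: the limit of > 2 h in this assay, at which 1 of the 4 values shown sits.

From the compounds shown here alone, a carboxylic acid, an amine or a longer chain at this place remains open. So does whether 1-hydroxy-1-methylethyl would read alike in place of the trifluoromethyl of compound 2.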